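This account rests on a few compounds, and the source may have more. Where it says the series, first, only, none or still open, it means among the compounds named here.

Measured so far in a functional assay on HT-29 cells (Homo sapiens) for inhibition, read by sulforhodamine B assay, with a stated time of 72 h; on this read-out higher numbers stand for weaker inhibition and lower numbers for stronger inhibition
- compound 1 `COc1cc(N2C(=O)CC2c2ccc(SC)cc2)cc(OC)c1OC` gives 108 nM 
- compound 2 `CCOc1ccc(C2C(C3CC3)C(=O)N2c2cc(OC)c(OC)c(OC)c2)cc1` gives 63 nM 
- compound 3 `COc1cc(N2C(=O)C(Oc3ccccc3)C2c2ccc(SC)cc2)cc(OC)c1OC` gives 336 nM 

Compound 3 has the highest number of the three, beyond the scatter from both others. The next change leads to compound 4 `COc1cc(N2C(=O)C(C3CC3)C2c2ccc(SC)cc2)cc(OC)c1OC` and puts cyclopropyl in place of phenoxy on a saturated ring carbon while the 4-(methylsulfanyl)phenyl group stays. Going by the values given here, the only measured step at this place is the phenoxy step (a 3.1-fold higher number from compound 1 to compound 3 (0.49 log units; beyond the scatter)), which is modest but beyond the scatter. Losing phenoxy should undo that step, provided cyclopropyl behaves like hydrogen here. Compound 2 supports this: it also carries cyclopropyl, though with ethoxy instead of methylsulfanyl, and its value (63 nM) lies within the scatter of compound 1 (108 nM). Among the compounds with values here, no measured pair isolates cyclopropyl itself, so the range stays wide. In this assay a step to a lower number is expected, somewhat larger than the phenoxy step (expected: a 4.2-fold lower number from compound 3 to compound 4 (0.62 log units; beyond the scatter)). Compound 4 is estimated at 80 nM (expected range 30 nM to 200 nM).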

Compound 4, half-maximal inhibitory concentration: 204 nM
Compound 4: the middle estimate sits 2.6-fold (0.41 log units) below what was measured, outside the stated range (above it).
By their numbers in this assay, from the lowest: compounds 2, 1, 4 and 3 (each within the scatter of the next, the first and the last beyond it).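

In this assay, cyclopropyl on this saturated ring carbon cannot be told apart from phenoxy (a 1.6-fold lower number from compound 3 to compound 4 (0.22 log units; within the scatter)) or from hydrogen (a 1.9-fold higher number from compound 1 to compound 4 (0.28 log units; within the scatter)), so the phenoxy step is now the only one at this position that lies beyond the scatter. With cyclopropyl held constant, the aromatic substituent gives a step beyond the scatter (a 3.2-fold higher number from compound 2 to compound 4 (0.51 log units; beyond the scatter)), so the value of compound 2 cannot be carried over to a methylsulfanyl compound bearing cyclopropyl. Nothing available explains either result.

Still open, from the compounds shown here alone, is whether the ethoxy and methylsulfanyl difference persists with hydrogen or phenoxy on this carbon. Also open, going by these compounds, is how an amine or a carboxylic acid at this position would compare with hydrogen.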